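The source may report more compounds than this note shows. Statements on the series, on what has been measured and on what is new or still open speak of the compounds shown alone.

Compound 1 `Cc1ccccc1Nc1nc(NCc2ccncc2)ncc1Cl` gives > 100000 nM in a functional assay on Jurkat cells (Homo sapiens) for inhibition, read by CCK-8 assay, with a stated time of 48 h (a lower number here means a stronger inhibitor of growth, a higher number a weaker inhibitor of growth), a limit of the assay rather than a number.
Compound 2 `Cc1ccccc1Nc1nc(Nc2ccc(N3CCN(C)CC3)cn2)ncc1Cl` gives 8080 nM in this assay.
Compound 3 `Cc1ccccc1Nc1nc(Nc2ccc(N3CCNCC3)cn2)ncc1Cl` gives 7870 nM in this assay.

Compound 2 stands at the higher of the two numbers reported, with compound 3 nearest: a 1.0-fold lower number from compound 2 to compound 3 (0.01 log units; within the scatter). Compound 4 `Cc1cccc(Nc2nc(Nc3ccc(N4CCN(C)CC4)cn3)ncc2Cl)c1` differs from compound 2 in one place: 3-methylphenyl in place of 2-methylphenyl on a nitrogen on an aromatic ring. Going by the values given here, the single measured step concerns the amine nitrogen in a ring, not the methylphenyl group, so no measured step bears on this change. With no guidance, the expected step from compound 2 to compound 4 is none beyond the scatter, written as a 1.2-fold higher number from compound 2 to compound 4 (0.09 log units; within the scatter), with wide uncertainty. Compound 4 is therefore estimated at 10000 nM, ranging from 3000 nM to 40000 nM.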

Compound 4, concentration for 50% growth inhibition: 15300 nM
For compound 4 the middle estimate is 1.5-fold (0.18 log units) below the measured one; measured number inside the range.
By their numbers in this assay, from the lowest: compounds 3, 2 and 4 (each within the scatter of the next). At a limit, above all of these: compound 1.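

With 3-methylphenyl in place of 2-methylphenyl on a nitrogen on an aromatic ring, this assay gives a 1.9-fold higher number from compound 2 to compound 4 (0.28 log units; within the scatter). Going by these compounds alone, this is the only measured step at this group, as the earlier step concerned the amine nitrogen in a ring, and it shows that this change of methylphenyl group does not separate the two compounds beyond the scatter. Nothing measured here bears on this step. The compounds shown leave open whether 4-methylphenyl, unsubstituted phenyl or a longer chain such as ethyl on the phenyl ring would give a number beyond the scatter.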